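Pyrazole Chalcones at One Dose: Amino Ketone Analogue Expected

The source may report more compounds than this note shows. Statements on the series, on what has been measured and on what is new or still open speak of the compounds shown alone.

Measured compounds:
compound 1 `COc1cc(-c2cc(/C=C/C(=O)c3ccc(N)cc3)[nH]n2)cc(OC)c1OC`: 94%
compound 2 `COc1ccc(C(=O)/C=C/c2cc(-c3cc(OC)c(OC)c(OC)c3)n[nH]2)cc1OC`: 92%
compound 3 `COc1ccc(C(=O)/C=C/c2cc(-c3cc(OC)c(OC)c(OC)c3)n[nH]2)cc1`: 102%

In a functional assay on K562 cells (Homo sapiens) for cytotoxicity, read by sulforhodamine B assay, with a stated time of 48 h, tested at 0.1 uM (a higher number here means a weaker effect of the compound at the concentration tested, a lower number a stronger effect), compound 1 gives 94%. The three measured compounds lie close together: a number 2 percentage points lower from compound 1 to compound 2 (within the scatter), a number 8 percentage points higher from compound 1 to compound 3 (within the scatter) and a number 10 percentage points higher from compound 2 to compound 3 (within the scatter). Compound 4 `COc1ccc(-c2cc(/C=C/C(=O)c3ccc(N)cc3)[nH]n2)cc1OC` awaits measurement. It differs from compound 1 by hydrogen in place of methoxy on an aromatic carbon. The same kind of change separates compound 2 from compound 3, (hydrogen in place of methoxy on an aromatic carbon), though the place in compound 1 is also described as meta to a methoxy group. The two cores differ by 4-aminophenyl in place of 3,4-dimethoxyphenyl on a carbonyl carbon. Because a number 10 percentage points higher from compound 2 to compound 3 (within the scatter) stayed within the scatter, the step expected for compound 4 is a number 4 percentage points higher from compound 1 to compound 4 (within the scatter). Compound 4 is therefore estimated at 98%, between 86% and 110%.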

Compound 4, a percentage reported as activity, at one concentration (the size of the read-out at that concentration, not a potency): 98%
Beside the measured number, compound 4's estimate shows no gap at the digits printed; low and high end bracket the measured number.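

In this assay hydrogen in place of methoxy on an aromatic carbon gives a number 4 percentage points higher from compound 1 to compound 4 (within the scatter) and can be set beside the same change on the other core: the same change on two cores in this assay, a number 10 percentage points higher (within the scatter) from compound 2 to compound 3 and a number 4 percentage points higher (within the scatter) from compound 1 to compound 4, 6 percentage points apart, within the scatter of two such steps. Within the data shown here, on these two cores, then, the change carries over with no difference between its steps that stands out from the scatter. This does not show that the two cores respond alike in general, since all the read-outs come from one concentration and lie close together, and two cores set no rule for the series.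

The compounds shown leave open what a butoxy chain or a carboxylic acid would do in place of the methoxy group. They also leave open whether any change on these cores would produce a step beyond the scatter at this concentration.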